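The compounds below may be only part of what the source reports. "The series", "measured", "known", "first", "only" and "open" are said of these compounds alone.

Series notes. Compound 3 `O=C(NO)c1ccc(Cc2nnc(Cc3cccc4ccccc34)o2)cc1` carries a hydroxycarbamoyl group; in an assay on isolated protein for inhibition of histone deacetylase 4 (Homo sapiens), read by fluorescence, with a stated time of 15 min (on this read-out lower numbers stand for stronger inhibition and higher numbers for weaker inhibition), compound 3 gives 7800 nM. Compound 1 `Nc1ccccc1NC(=O)c1ccc(Cc2nnc(Cc3cccc4ccccc34)o2)cc1` differs from it by 2-aminophenyl in place of hydroxy on an amide-type nitrogen. In this assay compound 1 reaches only the limit of > 20000 nM. The resulting step is an at least 2.5-fold higher number from compound 3 to compound 1 (0.40 log units; beyond the scatter), a size that rests on (the limit of > 20000 nM in this assay, at which 2 of the 3 values shown sit).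

Compound 2 `O=C(/C=C/c1ccc(-c2nnc(Cc3cccc4ccccc34)o2)cc1)NO` is built on another core; the difference between the two cores is not broken down here. In this assay compound 2 sits at the limit of > 20000 nM.

Compound 4 `Nc1ccccc1NC(=O)/C=C/c1ccc(-c2nnc(Cc3cccc4ccccc34)o2)cc1` is still to be measured in this assay. It differs from compound 2 by 2-aminophenyl in place of hydroxy on an amide-type nitrogen, the same change made from compound 3 to compound 1. Resting on an at least 2.5-fold higher number from compound 3 to compound 1 (0.40 log units; beyond the scatter), the step expected for compound 4 is a step that the limit leaves unreadable from compound 2 to compound 4. Compound 4 is therefore estimated at 60000 nM in this assay, most probably reported again only as a limit.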

Compound 4, half-maximal inhibitory concentration: > 20000 nM
Compound 4: no number, only a limit (the forecaster's own chance of this, stated with the estimate: 90%); the middle value does not contradict the limit.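

In this assay no step can be read from compound 2 to compound 4, as both rest on a limit: the limit of > 20000 nM in this assay, at which 3 of the 4 values shown sit.

The compounds shown leave open whether 2-aminophenyl in place of hydroxy changes the read-out on the core of compound 2.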